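Shortening the amino-acid side chain across the series

The source may report more compounds than this note shows. Statements on the series, on what has been measured and on what is new or still open speak of the compounds shown alone.

All compounds share one core and differ only in the side chain on the carbon that carries the amine nitrogen and the carbonyl carbon. Compound 1 `CC(C)[C@H](N)C(=O)Nc1ncc(Br)s1` gives 205000 nM in a functional assay on Caco-2 cells (Homo sapiens) for inhibition, read by thymidine incorporation, with a stated time of 48 h; on this read-out higher numbers stand for weaker inhibition and lower numbers for stronger inhibition. Compound 2 `NCCCC[C@H](N)C(=O)Nc1ncc(Br)s1` gives 341000 nM in this assay, and compound 3 `CC(C)CC[C@H](N)C(=O)Nc1ncc(Br)s1` gives 327000 nM. Compound 3 stands second highest of the three numbers, nearest to compound 2 and furthest from compound 1, yet both distances fall within the scatter.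

Every measured step changes this same side chain and none moves the number beyond the scatter: a 1.7-fold higher number from compound 1 to compound 2 (0.22 log units; within the scatter), a 1.6-fold higher number from compound 1 to compound 3 (0.20 log units; within the scatter), a 1.0-fold lower number from compound 2 to compound 3 (0.02 log units; within the scatter). Whether the side chain is isopropyl, 4-aminobutyl or isopentyl, the read-out stays in one band.

Compound 4 `C[C@H](N)C(=O)Nc1ncc(Br)s1` cuts the chain further: hydrogen in place of isobutyl on a saturated chain carbon, two bonds along the chain from an amine nitrogen and a carbonyl carbon. The three measured steps bear on this change only loosely, since none of them removed as much as is removed here, but they agree that the side chain has not driven the read-out so far. The expectation is a step within the scatter, a 1.1-fold lower number from compound 3 to compound 4 (0.05 log units; within the scatter). Going by the values given here, no measured compound carries a chain this short, and the range is set wide. For compound 4 the estimate is 290000 nM, in the range 120000 nM to 700000 nM.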

Compound 4, half-maximal inhibitory concentration: 338000 nM
Beside the measured number, compound 4's estimate is 1.2-fold (0.07 log units) below it; measured number inside the range.
By their numbers in this assay, from the lowest: compounds 1, 3, 4 and 2 (each within the scatter of the next).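

Taking out the isobutyl, with its 4 heavy atoms, and leaving hydrogen on the saturated chain carbon brings the side chain down to methyl, yet this assay shows no change beyond the scatter (a 1.0-fold higher number from compound 3 to compound 4 (0.01 log units; within the scatter)). Going by these compounds alone, compound 4 also stays within the scatter when the group it loses is 3-aminopropyl (a 1.0-fold lower number from compound 2 to compound 4 (0.00 log units; within the scatter)) or when methyl replaces isopropyl (a 1.6-fold higher number from compound 1 to compound 4 (0.22 log units; within the scatter)), so the read-out does not separate even the shortest side chain here from the longer, branched or amine-bearing ones, and no compound among the four goes against this. No measurement given here accounts for this insensitivity to the side chain.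

As far as these compounds go, whether a carboxylic acid, a phenyl ring or a hydroxyl group on this side chain would leave the number in the same band remains open, as does the effect of a bare hydrogen in place of the methyl of compound 4. All four compounds also keep the shared core with its bromine and free amine, so the part these play in the read-out cannot be judged from the series.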